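A propyl chain in place of the methylphenyl group

This account rests on a few compounds, and the source may have more. Where it says the series, first, only, none or still open, it means among the compounds named here.

Compound 1 `COc1cc2c(cc1OC)C(=O)C(CC1CCN(C(=S)Nc3cccc(C)c3)CC1)C2` and compound 2 `COc1cc2c(cc1OC)C(=O)C(CC1CCN(C(=S)Nc3ccc(C)cc3)CC1)C2` share one core and differ only at an amide-type nitrogen. In a functional assay on the whole organism (strain Swiss albino) with Mus musculus as the target, in the maximal electroshock model, with a stated time of 0.5 h (a lower number here means that less compound is needed, a higher number that more compound is needed for the effect), compound 1 gives 300 mg/kg, while compound 2 gives 30 mg/kg, the lowest of the two numbers, reached by a 10-fold lower number from compound 1 to compound 2 (1.00 log units; beyond the scatter). Compound 3 `CCCNC(=S)N1CCC(CC2Cc3cc(OC)c(OC)cc3C2=O)CC1` differs from compound 2 by propyl in place of 4-methylphenyl on an amide-type nitrogen. Going by the values given here, the single measured step concerns only where a methyl sits on the aromatic ring, so it bears weakly on swapping that ring for a chain. Compound 3 is therefore estimated at 100 mg/kg, within 30 mg/kg to 300 mg/kg. The expected step of a 3.3-fold higher number from compound 2 to compound 3 (0.52 log units; beyond the scatter) is modest, toward a higher number.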

Compound 3, minimum effective dose: 100 mg/kg
The estimate for compound 3 equals the measured number at the digits printed; the measured number falls inside the stated range.
By their numbers in this assay, from the lowest: compound 2; then compound 3; then compound 1.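

With propyl on the amide-type nitrogen in this assay, a 3.3-fold higher number from compound 2 to compound 3 (0.52 log units; beyond the scatter), while a 3.0-fold lower number from compound 1 to compound 3 (0.48 log units; beyond the scatter). Compound 3 thus lies between the two methylphenyl compounds, so the aromatic ring is not needed for a measurable effect, and the direction of the change depends on which methylphenyl compound it is read against. Nothing available explains these differences.

Still open, as far as these compounds go, is whether a longer chain, such as hexyl, or a benzyl group on this nitrogen would fall below compound 2 or rise above compound 3.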